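The compounds below may be only part of what the source reports. "The series", "measured", "known", "first", "only" and "open" are said of these compounds alone.

Measured compounds:
- compound 1 `O=C(/C=C(/C=C/c1ccc(O)cc1)NCCCO)/C=C/c1ccc(O)cc1`, which in a functional assay, read by spectrophotometry, with a stated time of 30 min (on this read-out higher numbers stand for an effect only at larger amounts of compound and lower numbers for an effect already at smaller amounts), gives 154000 nM
- compound 2 `COc1cc(/C=C/C(=O)/C=C(/C=C/c2ccc(O)c(OC)c2)NCCCO)ccc1O`, which in this assay gives 27600 nM
- compound 3 `COCCNC(=C\C(=O)/C=C/c1ccc(O)cc1)/C=C/c1ccc(O)cc1`, which in this assay reaches only a limit, > 200000 nM

Compound 2 gives the lowest number of the two measured ones; how its core differs from that of compound 1 is not broken down here. The change from compound 1 to compound 3 is methoxy in place of hydroxymethyl on a saturated chain carbon, two bonds along the chain from an amine nitrogen, and the step it made is an at least 1.2-fold higher number from compound 1 to compound 3 (0.11 log units; that floor lies within the scatter); that step is only a floor because of the limit of > 200000 nM in this assay, at which 1 of the 3 values shown sits. Compound 4 `COCCNC(=C\C(=O)/C=C/c1ccc(O)c(OC)c1)/C=C/c1ccc(O)c(OC)c1` has not yet been measured. It differs from compound 2 by methoxy in place of hydroxymethyl on a saturated chain carbon, two bonds along the chain from an amine nitrogen, the same change seen between compound 1 and compound 3. From compound 2 to compound 4 the step in this assay is expected to be a 2.0-fold higher number from compound 2 to compound 4 (0.30 log units; within the scatter), resting on the measured step of an at least 1.2-fold higher number from compound 1 to compound 3 (0.11 log units; that floor lies within the scatter), which pointed toward a higher number. Compound 4 is therefore estimated to give 55000 nM, between 25000 nM and 150000 nM.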

Compound 4, half-maximal effective concentration in the functional assay: 27300 nM
Compound 4: middle estimate off by 2.0-fold (0.30 log units), on the high side; low and high end bracket the measured number.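

In the functional assay, compound 2 gives 27600 nM and compound 4 gives 27300 nM; methoxy in place of hydroxymethyl gives a 1.0-fold lower number from compound 2 to compound 4 (0.00 log units; within the scatter), so on this core the two compounds cannot be told apart. Set beside the same change on the core of compound 1, this result does not settle whether the two cores respond alike: the same change on two cores in the functional assay, an at least 1.2-fold higher number (0.11 log units; that floor lies within the scatter) from compound 1 to compound 3 and a 1.0-fold lower number (0.00 log units; within the scatter) from compound 2 to compound 4; the limit leaves it open whether they differ. Compound 3 sits at a limit, so the step on the core of compound 1 is only a floor, and this shows neither that the change carries over nor that it fails to: the limit of > 200000 nM in the functional assay, at which 1 of the 4 values shown sits.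

In a physicochemical assay for solubility, using the shake flask method, in phosphate buffer, with a stated time of 24 h, at pH 6.8 (a higher number here means a more soluble compound, a lower number a less soluble compound), compound 2 gives 56300 nM and compound 4 gives 12700 nM; the same change gives a 4.4-fold lower number from compound 2 to compound 4 (0.65 log units; beyond the scatter), and the compounds shown leave open whether this holds on the core of compound 1. Also open, going by these compounds, is how a longer chain, or a carboxylic acid in place of the methoxy, would compare.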